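The source may hold more compounds than are shown below. What is called first, only, known or untested is meant among the compounds shown, and "the series" means these compounds.

Compound 1 `CN1C[C@H](C(=O)Nc2ccc(C#N)cc2)[C@@H](c2ccc(/C=C/C(=O)Nc3ccccc3N)cc2)C1` and compound 2 `Cc1ccc(NC(=O)[C@H]2CN(C)C[C@@H]2c2ccc(/C=C/C(=O)Nc3ccccc3N)cc2)cn1` share one core and were both measured in an in vitro ADME assay on microsomes from liver (Mus musculus) for pharmacokinetics, read by LC-MS, with a stated time of 10 min, tested at 1 uM; on this read-out higher numbers stand for fast clearance and lower numbers for slow clearance. For the measured compounds named here, compound 1 gives 35 mL/min/kg, the lowest of the two numbers, and compound 2 gives 57 mL/min/kg; the single measured step, a 1.6-fold higher number from compound 1 to compound 2 (0.21 log units; within the scatter), stays within the scatter. Compound 3 `CC(C)NC(=O)[C@H]1CN(C)C[C@@H]1c1ccc(/C=C/C(=O)Nc2ccccc2N)cc1` differs from compound 1 in one place: isopropyl in place of 4-cyanophenyl on an amide-type nitrogen. Going by the values given here, no measured step exchanges an aromatic group for a short chain, so that one step gives only loose guidance, and no shift beyond the scatter is expected in either direction. For compound 3 in this assay the estimate is 40 mL/min/kg, ranging from 18 mL/min/kg to 90 mL/min/kg, an expected step of a 1.1-fold higher number from compound 1 to compound 3 (0.06 log units; within the scatter).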

Compound 3, clearance: 12 mL/min/kg
Beside the measured number, compound 3's estimate is 3.3-fold (0.52 log units) above it; the whole stated range lies above it.
By their numbers in this assay, from the lowest: compound 3; then compounds 1 and 2 (each within the scatter of the next).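

Isopropyl on the amide-type nitrogen gives the first change beyond the scatter at this position: a 2.9-fold lower number from compound 1 to compound 3 (0.46 log units; beyond the scatter), and a 4.8-fold lower number from compound 2 to compound 3 (0.68 log units; beyond the scatter). So this position can shift clearance, although 4-cyanophenyl and 6-methylpyridin-3-yl, the two aromatic groups, sit within the scatter of each other. Nothing available explains why clearance is lower with isopropyl. From the compounds shown here alone, it remains open whether this result belongs to isopropyl alone or extends to other groups without a ring. A longer chain, a tert-butyl group or a cyclohexyl ring on the same nitrogen would help separate these possibilities.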